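This account rests on a few compounds, and the source may have more. Where it says the series, first, only, none or still open, it means among the compounds named here.

Compound 1 `Cc1ccc(S(=O)(=O)N2CCC(Cl)CC2)cc1`, compound 2 `CCCCCCC[C@H]1C[C@H](Br)CCN1S(=O)(=O)c1ccc(C)cc1` and compound 3 `Cc1ccc(S(=O)(=O)N2CC=C(Cl)CC2)cc1` were each examined in a functional assay on SW1573 cells (Homo sapiens) for antiproliferative activity, read by sulforhodamine B assay, with a stated time of 48 h; a lower number here means a stronger inhibitor of growth, a higher number a weaker inhibitor of growth. For compound 1 the result is a limit of the assay rather than a number, > 100000 nM. Compound 2 likewise gives only a limit, > 100000 nM. Compound 3 too gives a limit in this assay, > 100000 nM. Among the compounds with values here, compound 3 therefore stands where every measured compound stands: all three sit at the limit of > 100000 nM in this assay, at which 3 of the 3 values shown sit, and no step between measured compounds can be traced.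

Compound 4 `CCCCCCCC1C=C(Cl)CCN1S(=O)(=O)c1ccc(C)cc1` is not yet measured. It differs from compound 3 in one place: heptyl in place of hydrogen on a saturated ring carbon. Compound 2 also carries a heptyl chain and gives only a limit, > 100000 nM. Within the data shown here, no measured step gives a size or a direction for this change, so no shift beyond the scatter is expected, and compound 4 is expected to remain at the limit as well. In this assay compound 4 is estimated at 150000 nM, within 50000 nM to 500000 nM. The step that the limit leaves unreadable from compound 3 to compound 4 that this estimate means is expected to lie within the scatter.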

Compound 4, concentration for 50% growth inhibition: 49000 nM
Estimate against measurement, compound 4: 3.1-fold (0.49 log units) above, and the stated range ends above it.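

Within the data shown here, at this position, on a saturated ring carbon next to the ring nitrogen, heptyl in place of hydrogen gives the first change that can be read in this assay: an at least 2.0-fold lower number from compound 3 to compound 4 (0.30 log units; that floor lies within the scatter). As far as these compounds go, compound 3 holds only a limit, so this figure is a floor: the real size of the step stays unknown, and the floor itself does not clear the usual scatter. Compound 4 is the only one of the four compounds with a number rather than a limit: the limit of > 100000 nM in this assay, at which 3 of the 4 values shown sit.

The compounds shown leave open how growth inhibition depends on the chain at this position, since no shorter chain such as propyl, no longer chain such as decyl and no ring such as phenyl stands there. They also leave open whether a chain ending in an amine or a carboxylic acid would serve in place of heptyl.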